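A few compounds are considered here, and "the series" means these few. Any claim that something is new, unique, unknown or untested is made for them only; others in the source may bear on it.

Measured compounds:
- Compound 1, `Cc1cc(F)cc(C)c1Oc1ccc(C(C)(C)O)cc1-c1cn(C)c(=O)c2[nH]c(C(=O)NCCCCCCC(=O)NO)cc12`: 17.2 nM
- Compound 2, `Cn1cc(-c2cc(C(C)(C)O)ccc2OC2CC2)c2cc(C(=O)NCCCCCCC(=O)NO)[nH]c2c1=O`: 5.5 nM
- Compound 3, `Cn1cc(-c2cc(C(C)(C)O)ccc2OC2CC2)c2cc(C(=O)NCc3ccc(C(=O)NO)cc3)[nH]c2c1=O`: 7.9 nM

All three were tested in an assay on isolated protein for inhibition of protein deacetylase HDAC6 (Homo sapiens), read by fluorescence; on this read-out higher numbers stand for weaker inhibition and lower numbers for stronger inhibition. Compound 2 gives the lowest number of the three; compound 3 lies within the scatter of it, so no difference between those two can be claimed, while the step of a 3.1-fold lower number from compound 1 to compound 2 (0.50 log units; beyond the scatter) lies beyond the scatter. That step swapped an aryl group on the ring oxygen for cyclopropyl.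

Compound 4, `Cn1cc(-c2cc(C(C)(C)O)ccc2Oc2ccc(F)cc2F)c2cc(C(=O)NCCCCCCC(=O)NO)[nH]c2c1=O`, has not yet been measured. It differs from compound 2 in one place: 2,4-difluorophenyl in place of cyclopropyl on an oxygen on an aromatic ring. Among the measured compounds shown here, this is close to the reverse of the only step that touched that position, since an aromatic group again replaces cyclopropyl on the same oxygen. For the measured compounds named here, the step of a 3.1-fold lower number from compound 1 to compound 2 (0.50 log units; beyond the scatter) is therefore the one measurement that bears on it, and on that basis a modest rise in the number, in this assay, is expected for compound 4, roughly a 2.4-fold higher number from compound 2 to compound 4 (0.37 log units; beyond the scatter). The estimate for compound 4 is 13 nM, with a likely range from 5 nM to 35 nM.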

Compound 4, half-maximal inhibitory concentration: 8.7 nM
Estimate against measurement, compound 4: 1.5-fold (0.17 log units) above; low and high end bracket the measured number.
By their numbers in this assay, from the lowest: compounds 2, 3, 4 and 1 (each within the scatter of the next, the first and the last beyond it).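

In this assay, the move a 1.6-fold higher number from compound 2 to compound 4 (0.20 log units; within the scatter) shows that an aromatic group on this oxygen need not read differently from cyclopropyl, as 2,4-difluorophenyl and cyclopropyl cannot be told apart here. The step of a 2.0-fold lower number from compound 1 to compound 4 (0.30 log units; within the scatter) means that compound 4 cannot be separated from the aryl-bearing compound 1 either, so it sits within the scatter of two compounds that lie beyond the scatter of each other, and the gap between those two does not extend to every aromatic group at this place. No measurement at hand gives a reason for these numbers.

Going by these compounds, whether an unsubstituted phenyl, or a chain ending in an amine or a carboxylic acid, would read the same on this oxygen stays open. Also open, on these data alone, is how 2,4-difluorophenyl behaves alongside the 4-(hydroxycarbamoyl)phenyl group of compound 3.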